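This account rests on a few compounds, and the source may have more. Where it says the series, first, only, none or still open, it means among the compounds named here.

Measured compounds in a functional assay on MV4-11 cells (Homo sapiens) for antiproliferative activity, with a stated time of 6 days, tested at 1.56 uM; on this read-out higher numbers stand for a stronger effect at the one concentration tested and lower numbers for a weaker effect:
- compound 1 `CNC(=O)N1CCCc2ccc(NC(=O)c3ccc(-c4ccn(C(C)=O)n4)cc3)cc21`: 35.8%
- compound 2 `CNC(=O)N1CCCc2ccc(NC(=O)c3ccc(-c4ccn(S(C)(=O)=O)n4)cc3)cc21`: 8.81%
- compound 3 `CNC(=O)N1CCCc2ccc(NC(=O)c3cccc(-c4cnn(S(C)(=O)=O)c4)c3)cc21`: 1.6%

Compound 2 and compound 3 carry the same atoms joined differently; the difference between the two cores is not broken down here. Within the core of compound 1, the change acetyl in place of methylsulfonyl on an aromatic nitrogen gave a number 27 percentage points higher from compound 2 to compound 1 (beyond the scatter).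

Compound 4 `CNC(=O)N1CCCc2ccc(NC(=O)c3cccc(-c4cnn(C(C)=O)c4)c3)cc21` is not yet measured. It arises from compound 3 by acetyl in place of methylsulfonyl on an aromatic nitrogen, the same change in the same place as before, read one bond further out as 1-(methylsulfonyl)-1H-pyrazol-4-yl to 1-acetyl-1H-pyrazol-4-yl. Because compound 3 starts low at 1.6% and the earlier step was a number 27 percentage points higher from compound 2 to compound 1 (beyond the scatter), the expected step is a number 20.4 percentage points higher from compound 3 to compound 4 (beyond the scatter), taken as a similar but less certain gain since the core differs. Compound 4 is therefore estimated at 22% in this assay, between 5% and 45%.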

Compound 4, a percentage reported as inhibition, at one concentration (the size of the read-out at that concentration, not a potency): 33.6%
For compound 4 the middle estimate is 11.6 percentage points below the measured one, within the range that was stated.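

In this assay, acetyl in place of methylsulfonyl on the aromatic nitrogen again gives a number 32 percentage points higher from compound 3 to compound 4 (beyond the scatter). The size of the step holds across the two cores: the same change on two cores in this assay, a number 27 percentage points higher (beyond the scatter) from compound 2 to compound 1 and a number 32 percentage points higher (beyond the scatter) from compound 3 to compound 4, 5 percentage points apart, within the scatter of two such steps. This shows that the change carries over between these two cores at the one concentration tested, but it gives no potency and, resting on two pairs, sets no rule for other cores in the series.

The compounds shown leave open how other groups on that aromatic nitrogen would compare, such as a propanoyl group, a longer acyl chain or a plain hydrogen. They also leave open whether the acetyl group itself is needed or whether another carbonyl group, such as a methyl carbamate, would serve equally well.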